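The source may report more compounds than this note shows. Statements on the series, on what has been measured and on what is new or still open speak of the compounds shown alone.

Working notes on the series. The shared core is held constant and the substituent on an aromatic carbon of the six-membered ring is varied. Compound 1 `CCCCCNc1nc(N)c2nc(O)n(Cc3ccccc3)c2n1` carries pentylamino at that position; in a functional assay on the whole organism for activation, with Mus musculus as the target (on this read-out higher numbers stand for an effect only at larger amounts of compound and lower numbers for an effect already at smaller amounts), compound 1 gives 0.3 mg/kg. Compound 2 `CSc1nc(N)c2nc(O)n(Cc3ccccc3)c2n1` carries methylsulfanyl instead, and in this assay compound 2 gives 0.1 mg/kg. Compound 3 `CCSc1nc(N)c2nc(O)n(Cc3ccccc3)c2n1` carries ethylsulfanyl, and in this assay compound 3 gives 0.1 mg/kg. Among the three measured compounds compound 1 stands at the highest number: a 3.0-fold lower number from compound 1 to compound 2 (0.48 log units; beyond the scatter) and a 3.0-fold lower number from compound 1 to compound 3 (0.48 log units; beyond the scatter), both beyond the scatter, while no change at the digits printed from compound 2 to compound 3 (within the scatter).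

Compound 4 `Cc1nc(N)c2nc(O)n(Cc3ccccc3)c2n1` is not yet measured. Relative to compound 1 the change is methyl in place of pentylamino on an aromatic carbon. Within the data shown here, the steps that bear on it are the two from compound 1, each replacing pentylamino by a short sulfanyl group and each lowering the number by a modest amount; the step from compound 2 to compound 3 adds that a further chain carbon makes no difference. Among the measured compounds shown here, no measured step shows a substituent without a heteroatom at this position, so the transfer is uncertain. The expected step is a modest lowering, a 2.0-fold lower number from compound 1 to compound 4 (0.30 log units; within the scatter), with a wide range. Compound 4 is estimated at 0.15 mg/kg, between 0.05 mg/kg and 0.6 mg/kg.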

Compound 4, minimum effective dose: 3 mg/kg
Compound 4: the middle estimate sits 20-fold (1.30 log units) below what was measured; measured number outside the range, above it.
By their numbers in this assay, from the lowest: compounds 2 and 3 (each within the scatter of the next); then compound 1; then compound 4.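

In this assay, among these compounds, this position proves far less tolerant than the earlier compounds suggested, since methyl gives the highest number of the series (a 10-fold higher number from compound 1 to compound 4 (1.00 log units; beyond the scatter); a 30-fold higher number from compound 2 to compound 4 (1.48 log units; beyond the scatter); a 30-fold higher number from compound 3 to compound 4 (1.48 log units; beyond the scatter)), and the two larger steps are the ones from the sulfanyl groups. Among these four compounds, every group attached through nitrogen or sulfur gives a lower number than methyl, and none goes against this, whereas chain length alone does not order them: methyl and methylsulfanyl are both short, yet they stand at opposite ends of the series. Nothing available explains this rise in the number.

The compounds shown do not separate the linking atom from the chain attached to it, so a pentyl chain joined directly through carbon, or a methoxy group, would be needed to tell the two apart. Also open, on these data alone, is the result with a plain hydrogen or a chloro substituent at this position, and whether pentylsulfanyl would match the shorter sulfanyl groups or stand nearer to pentylamino.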